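Carbamate-bearing side chain replaced by acetyl on the shared core

The source may hold more compounds than are shown below. What is called first, only, known or untested is meant among the compounds shown, and "the series" means these compounds.

Three compounds of the series have numbers in a functional assay on L1210 cells (Mus musculus), with a stated time of 1 days; on this read-out lower numbers stand for lower potency and higher numbers for higher potency (the scale is a negative logarithm). Compound 1 `CC1=C(N2CC2)C(=O)C(CC(C)OC(N)=O)=C(N2CC2)C1=O` gives 5.18 in this assay, the highest of the three. Compound 2 `COCCOC(COC(N)=O)C1=C(N2CC2)C(=O)C(C)=C(N2CC2)C1=O` gives 4.96, a number within the scatter of that of compound 1, so no order between these two can be read. Compound 3 `CCCC1=C(N2CC2)C(=O)C(CCOC(N)=O)=C(N2CC2)C1=O` gives 4.42, which lies beyond the scatter below compound 1.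

Compound 4 `CC(=O)C1=C(N2CC2)C(=O)C(C)=C(N2CC2)C1=O` is not yet measured in this assay. It differs from compound 1 in one place: a group of 3 heavy atoms (2 carbon, 1 oxygen; no ring) in place of a group of 7 heavy atoms (4 carbon, 1 nitrogen, 2 oxygen; no ring), on a double-bonded ring carbon The acetyl enters on a double-bonded ring carbon of a six-membered non-aromatic ring of carbon only, next to the ring atom that bears an aziridin-1-yl group and three ring bonds from the ring atom that bears a methyl group.

Going by the values given here, no step between two measured compounds that differ in a single place is available, so the size of this change has no precedent; the gap between compound 1 and compound 3 involves more than one change and cannot be read as a guide. A moderate fall in this assay is expected, of about a number 0.38 log units lower from compound 1 to compound 4 (beyond the scatter). Compound 4 is therefore expected to give 4.8 in this assay, with a range from 4.2 to 5.4.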

Compound 4, logarithm of the reciprocal of the active concentration, log(1/C): 3.48
Estimate against measurement, compound 4: 1.32 log units above; measured number outside the range, below it.
By their numbers in this assay, from the lowest: compound 4; then compound 3; then compounds 2 and 1 (each within the scatter of the next).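

In this assay, going by these compounds alone, acetyl in place of the carbamate-bearing side chain, on a double-bonded ring carbon of the shared core, gives a number 1.70 log units lower from compound 1 to compound 4 (beyond the scatter), the first step that isolates a change in one place. Within the data shown here, the result shows that the number in this assay depends strongly on what this ring carbon carries, something the earlier compounds could not show since none of them forms a single-place pair with another. The change swaps a group of 7 heavy atoms with 1 hydrogen-bond donor and 2 hydrogen-bond acceptors for one of 3 heavy atoms with 0 donors and 1 acceptor, and no measurement shown explains the fall or assigns it to any one of these differences.

With a single step, chain length, the carbamate and the ketone carbonyl directly on the ring remain entangled, so it stays open which of them accounts for the fall. A 2-hydroxyethyl chain or a 3-oxobutyl chain at this ring carbon would help separate them, the first keeping a hydrogen-bond donor without the carbamate and the second keeping a chain while ending in a ketone.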